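A larger branched group on a weak compound

This account rests on a few compounds, and the source may have more. Where it says the series, first, only, none or still open, it means among the compounds named here.

Compound 1 `C[C@@H](/N=c1\c(O)c(O)\c1=N/c1ccc(C#N)cc1)C(C)(C)C`: 370 nM; 24300 nM (2 entries)
Compound 2 `CC(C)(C)C/N=c1\c(O)c(O)\c1=N/c1ccc(C#N)cc1`: > 30000 nM, a limit
Compound 3 `C/N=c1\c(O)c(O)\c1=N/c1ccc(C#N)cc1`: > 30000 nM, a limit

In a functional assay for inhibition, with Rattus norvegicus as the target (a higher number here means a weaker inhibitor, a lower number a stronger inhibitor), compound 3 gives only a limit, > 30000 nM. That limit is shared with compound 2: the limit of > 30000 nM in this assay, at which 2 of the 3 values shown sit. For the measured compounds named here, the one measured step, a step that the two limits leave unreadable from compound 2 to compound 3, therefore gives no size to build on.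

Compound 4 `C[C@H](/N=c1\c(O)c(O)\c1=N/c1ccc(C#N)cc1)C1CCCCC1` carries a new group on the double-bonded nitrogen: 1-cyclohexylethyl in place of methyl on a double-bonded nitrogen.

Going by the values given here, the only real numbers come from compound 1, and its entries disagree widely: the several entries of compound 1 in this assay, 370 nM; 24300 nM (2 entries). Compound 1 still suggests that a branched group of this kind can bring a measurable value, while compound 2 shows that a large group alone does not guarantee one. A move toward a lower number in this assay, meaning stronger inhibition, is expected, though its size is very uncertain. The expected move is an at least 10-fold lower number from compound 3 to compound 4 (1.00 log units; beyond the scatter). For compound 4 the estimate is 3000 nM, with an expected range from 250 nM to 30000 nM.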

Compound 4, half-maximal inhibitory concentration: > 30000 nM
Compound 4: no number, only a limit; the forecaster's own chance of this, stated with the estimate: 30%; middle value at least 10-fold (1.00 log units) from the limit.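

In this assay compound 4 gives only a limit, > 30000 nM, and its steps to compound 2 and compound 3, which also give limits, cannot be read. The compounds shown leave open whether any group on the double-bonded nitrogen gives a firm value, given the widely separated entries of compound 1.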